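Lengthening the amine chain of compound 3

The source may report more compounds than this note shows. Statements on the series, on what has been measured and on what is new or still open speak of the compounds shown alone.

In a functional assay on the whole organism for inhibition, with Mus musculus as the target (a higher number here means that more compound is needed for the effect, a lower number that less compound is needed), compound 3 (`CCNCC(=O)Nc1cccc2c1CN(C)CC2c1ccccc1`) gives 47 mg/kg, within the scatter of compound 1 (`CCNC(=O)Nc1cccc2c1CN(C)CC2c1ccccc1`) at 80 mg/kg. Compound 2 (`CN1Cc2c(NC(=O)OCc3ccccc3)cccc2C(c2ccccc2)C1`) reads about 15 mg/kg, lower than both. Compound 4 (`CCCCNCC(=O)Nc1cccc2c1CN(C)CC2c1ccccc1`) differs from compound 3 by ethyl in place of hydrogen on a saturated chain carbon, two bonds along the chain from an amine nitrogen, or ethylamino to butylamino. Among the measured compounds shown here, no measured step alters this chain. The nearest evidence comes from changes on the carbonyl carbon: a 1.7-fold lower number from compound 1 to compound 3 (0.23 log units; within the scatter) and, larger and modest, a 5.3-fold lower number from compound 1 to compound 2 (0.73 log units; beyond the scatter) and a 3.1-fold higher number from compound 2 to compound 3 (0.50 log units; beyond the scatter). No step beyond the scatter is expected in this assay, though this rests on indirect evidence. The estimated step is a 1.2-fold lower number from compound 3 to compound 4 (0.07 log units; within the scatter). For compound 4 the expected value is 40 mg/kg, with an estimated range of 18 mg/kg to 90 mg/kg.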

Compound 4, dose for half-maximal effect: 32 mg/kg
Beside the measured number, compound 4's estimate is 1.3-fold (0.10 log units) above it; low and high end bracket the measured number.
By their numbers in this assay, from the lowest: compound 2; then compounds 4, 3 and 1 (each within the scatter of the next, the first and the last beyond it).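

In this assay, ethylamino to butylamino on this chain gives a 1.5-fold lower number from compound 3 to compound 4 (0.17 log units; within the scatter) and so stays within the scatter. The butylamino side chain does reach past the scatter against the ethylamino group on the carbonyl carbon, with a 2.5-fold lower number from compound 1 to compound 4 (0.40 log units; beyond the scatter) where compound 3 did not, yet the benzyloxy group keeps the lowest number, with a 2.1-fold higher number from compound 2 to compound 4 (0.33 log units; beyond the scatter) in this assay. Nothing available gives a reason for these steps.

Still open, on these data alone, is whether a longer chain such as hexylamino, or a ring amine such as piperidine, would move the number beyond the scatter from compound 4.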